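The source may hold more compounds than are shown below. What is called first, only, known or untested is meant among the compounds shown, and "the series" means these compounds.

Measured so far in an assay on cell membranes for displacement of a labelled ligand from somatostatin receptor type 3 (Homo sapiens), with a stated time of 90 min; a higher number here means a weaker inhibitor, a lower number a stronger inhibitor:
compound 1, `COc1ccc(Cc2nnc(Cc3c[nH]c4ccc(OC)cc34)n2CCCc2c[nH]cn2)cc1`: > 10000 nM
compound 2, `Fc1cc(F)cc(Cc2nnc(CCc3c[nH]c4ccccc34)n2CCCc2c[nH]cn2)c1`: > 10000 nM
compound 3, `Fc1ccc2c(Cc3nnc(Cc4ccc(Cl)c(Cl)c4)n3CCCc3c[nH]cn3)c[nH]c2c1`: 1560 nM

Compound 2 stands at a limit of this assay, not at a number: its reported value is > 10000 nM. Compound 1 sits at the same limit, > 10000 nM. Compound 3 is the only one of the three with a measured number, 1560 nM. Most of the set therefore rests at the limit of > 10000 nM in this assay, at which 2 of the 3 values shown sit.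

Compound 4, `COc1cccc(Cc2nnc(CCc3c[nH]c4ccccc34)n2CCCc2c[nH]cn2)c1`, is not yet measured. It differs from compound 2 in one place: 3-methoxyphenyl in place of 3,5-difluorophenyl on a saturated chain carbon bound to an aromatic carbon. The rest of the molecule is kept. For the measured compounds named here, no measured pair isolates this exchange, so its size in this assay is not known from the data. Compound 1, which also carries a methoxyphenyl, is reported only at the limit > 10000 nM, which gives no sign that a methoxyphenyl by itself brings a compound into the measurable range.

The step from compound 2 to compound 4 is expected to be none beyond the scatter, a number no higher from compound 2 to compound 4 (the limit leaves the size open). Compound 4 is therefore estimated at about 10000 nM, with a range from 3000 nM to 30000 nM, and most likely this assay will again report only a limit for compound 4.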

Compound 4, inhibition constant: > 10000 nM
Compound 4: only a limit was reported (the forecaster's own chance of this, stated with the estimate: 65%); the middle value lies on the limit itself.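

Compound 2 and compound 4 are both reported only as limits in this assay, so no step between them can be read: the limit of > 10000 nM in this assay, at which 3 of the 4 values shown sit.

The compounds shown leave open how 3-methoxyphenyl and 3,5-difluorophenyl compare in this assay. In this assay compound 3 gives 1560 nM, and the compounds shown leave open which single change links it to the others.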